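The source may report more compounds than this note shows. Statements on the series, on what has been measured and on what is new or still open speak of the compounds shown alone.

Measured so far in an in vitro functional assay on cells (Fibroblast) for agonist activity at Alpha-1A adrenergic receptor (Homo sapiens); on this read-out lower numbers stand for an effect already at smaller amounts and higher numbers for an effect only at larger amounts of compound:
- compound 1 `Cc1n[nH]c(-c2ccccc2NCC2=NCCN2)n1` gives 794 nM
- compound 2 `Cn1cc(-c2ccccc2NCC2=NCCN2)cn1` gives 398 nM

Among the compounds with values here, compound 2 has the lower of the two numbers in this assay, but its only neighbour is compound 1, and the step of a 2.0-fold lower number from compound 1 to compound 2 (0.30 log units; within the scatter) lies within the scatter, so the two values count as the same.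

The next compound is compound 3 `Cn1cccc1-c1ccccc1NCC1=NCCN1`, not yet measured in this assay. It differs from compound 2 in one place: 1-methyl-1H-pyrrol-2-yl in place of 1-methyl-1H-pyrazol-4-yl on an aromatic carbon. Within the data shown here, the one measured step that bears on this, a 2.0-fold lower number from compound 1 to compound 2 (0.30 log units; within the scatter), also exchanged one five-membered aromatic ring for another on the same aromatic carbon and stayed within the scatter. Among the measured compounds shown here, the series therefore gives no sign that this position is sensitive to the choice of five-membered ring; the data cover only two such rings and no pyrrole, so the expectation is loose.

For compound 3 the expected step is a 1.0-fold higher number from compound 2 to compound 3 (0.00 log units; within the scatter), meaning no change beyond the scatter. The estimate for compound 3 in this assay is 400 nM, with a range from 130 nM to 1300 nM.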

Compound 3, half-maximal effective concentration: 20 nM
Beside the measured number, compound 3's estimate is 20-fold (1.30 log units) above it; the measured number lies below the stated range.
By their numbers in this assay, from the lowest: compound 3; then compounds 2 and 1 (each within the scatter of the next).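

In this assay, within the data shown here, this aromatic carbon proves sensitive to the choice of five-membered aromatic ring: 1-methyl-1H-pyrrol-2-yl in place of 1-methyl-1H-pyrazol-4-yl gives a 20-fold lower number from compound 2 to compound 3 (1.30 log units; beyond the scatter), and the same group in place of 3-methyl-1H-1,2,4-triazol-5-yl gives a 40-fold lower number from compound 1 to compound 3 (1.60 log units; beyond the scatter), whereas the one earlier exchange at this carbon stayed within the scatter. The entering ring has one hetero atom and one hydrogen-bond acceptor against two of each in the 1-methyl-1H-pyrazol-4-yl group, and the two names also differ in the point of attachment, so these differences change together and the steps cannot separate them. No measurement at hand accounts for the size of these steps.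

Still open, as far as these compounds go, is which feature of the 1-methyl-1H-pyrrol-2-yl group goes with the lower number: an unsubstituted 1H-pyrrol-2-yl, a 1-methyl-1H-pyrrol-3-yl or a 1-methyl-1H-pyrazol-5-yl group at this carbon would pull apart the methyl group, the point of attachment and the second ring nitrogen. Equally open, from the compounds shown here alone, is how a ring without nitrogen, such as thiophen-2-yl or phenyl, would read at this carbon.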